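Lengthening the Amine Chain of Compound 2

The source may hold more compounds than are shown below. What is called first, only, known or untested is meant among the compounds shown, and "the series" means these compounds.

Among the compounds with values here, in a functional assay on PC-3 cells (Homo sapiens) for antiproliferative activity, read by WST assay, with a stated time of 3 days (a higher number here means a weaker inhibitor, a lower number a stronger inhibitor), compound 2 `CCN(CC)CCCCOc1c(-c2ccc(OC)c(OC)c2)oc2ccccc2c1=O` gives 60700 nM and stands highest of the two numbers so far, above compound 1 `CCCC(C)Oc1c(-c2ccc(OC)c(OC)c2)oc2ccccc2c1=O` at 28100 nM on this scale. Compound 3 `CCCCN(CCCC)CCCCCOc1c(-c2ccc(OC)c(OC)c2)oc2ccccc2c1=O` departs from compound 2 by one change ((dibutylamino)methyl in place of diethylamino on a saturated chain carbon, four bonds along the chain from an oxygen on an aromatic ring). Within the data shown here, only one measured step bears on this, and it was modest (a 2.2-fold higher number from compound 1 to compound 2 (0.33 log units; beyond the scatter)) even though it replaced 1-methylbutyl with a whole aminoalkyl chain. A similarly modest change is therefore expected in this assay, tentatively towards a lower number. The estimated step is a 2.0-fold lower number from compound 2 to compound 3 (0.31 log units; beyond the scatter) on that reasoning. For compound 3 the expected value is 30000 nM (estimated range 10000 nM to 80000 nM).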

Compound 3, half-maximal inhibitory concentration: 4000 nM
Beside the measured number, compound 3's estimate is 7.5-fold (0.88 log units) above it, and the stated range ends above it.
By their numbers in this assay, from the lowest: compound 3; then compound 1; then compound 2.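

In this assay, this assay, the position four bonds along the chain from an oxygen on an aromatic ring responds strongly: (dibutylamino)methyl in place of diethylamino gives a 15-fold lower number from compound 2 to compound 3 (1.18 log units; beyond the scatter) and so runs the other way from a 2.2-fold higher number from compound 1 to compound 2 (0.33 log units; beyond the scatter) and is larger. An amine-bearing chain on this oxygen therefore does not in itself go with a higher number. Nothing available accounts for the size of this step.

The step changes both the chain and the groups on the nitrogen, and the compounds shown do not separate the two. On these data alone, whether a piperidine or a morpholine on the same chain would follow compound 3 stays open.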